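A few compounds are considered here, and "the series" means these few. Any claim that something is new, unique, unknown or untested is made for them only; others in the source may bear on it.

Among the measured compounds shown here, in a physicochemical assay for lipophilicity, using the shake flask method, measured as octanol-water partition, at pH 7.4 (a higher number here means a more lipophilic compound, a lower number a more polar compound), compound 1 (`NC(=O)c1cnc2ccc(-c3cccnc3)cc2c1NC1CCCC1`) gives 3.6, the higher of the two numbers available so far. Compound 2 (`CCC(CC)CNc1c(C(N)=O)cnc2ccc(-c3ccc(CS(C)(=O)=O)nc3)cc12`) gives 3.1, and this gap lies beyond the scatter. Compound 3 (`CCC(CC)COc1c(C(N)=O)cnc2ccc(-c3cccnc3)cc12`) keeps the core of compound 1 but carries 2-ethylbutoxy in place of cyclopentylamino on an aromatic carbon, ortho to a carbamoyl group and opposite the ring nitrogen: 2-ethylbutoxy in place of cyclopentylamino on an aromatic carbon. For the measured compounds named here, no measured pair isolates this exchange, and compounds 1 and 2 differ in more than one place, so their gap offers no direct guide. The expectation therefore rests only on the counted change, starting from compound 1 at 3.6. In this assay, a modest rise just beyond the scatter is expected, with the estimated step of a number 0.40 log units higher from compound 1 to compound 3 (beyond the scatter). The estimated value for compound 3 is 4, with an expected range from 3.5 to 4.5.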

Compound 3, distribution coefficient: > 4.3
Compound 3: no number, only a limit; the forecaster's own chance of this, stated with the estimate: 5%; at least 0.30 log units between middle value and limit.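

In this assay compound 3 reads > 4.3, which is a limit of the assay and not a number. Among the compounds shown here, the exchange of cyclopentylamino for 2-ethylbutoxy on this aromatic carbon, ortho to a carbamoyl group and opposite the ring nitrogen, is the only change in one place available, and it amounts to a number at least 0.70 log units higher from compound 1 to compound 3 (beyond the scatter). The step has a lower bound only, and its full size stays unread: the limit of > 4.3 in this assay, at which 1 of the 3 values shown sits.

The exchange removes a ring and replaces the attaching nitrogen with oxygen in a single move, and the compounds shown do not separate the two changes. A cyclopentyloxy group on this carbon would keep the ring and alter only the attaching atom, while a short methoxy group would show how far the reading depends on chain size.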